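The source may report more compounds than this note shows. Statements on the series, on what has been measured and on what is new or still open speak of the compounds shown alone.

Compound 1 `Oc1cccc(-c2cc(-c3ccc(Cl)cc3)nc(-c3cccs3)c2)c1` gives 10500 nM in a functional assay on T47D cells (Homo sapiens) for cytotoxicity, read by CCK-8 assay and cell counting, with a stated time of 2 days; a higher number here means a weaker inhibitor, a lower number a stronger inhibitor. It stands level with compound 3 `Oc1cccc(-c2cc(-c3ccc(Cl)cc3)nc(-c3ccco3)c2)c1`, which gives 10500 nM in this assay, and together they hold the lowest of the three numbers, while compound 2 `Oc1cccc(-c2cc(-c3ccc(Cl)cc3)nc(-c3ccsc3)c2)c1` gives 11500 nM in this assay; the step of a 1.1-fold higher number from compound 1 to compound 2 (0.04 log units; within the scatter) and the step of no change at the digits printed from compound 1 to compound 3 (within the scatter) both lie within the scatter. Compound 4 `Oc1cccc(-c2cc(-c3cccc(Cl)c3)nc(-c3cccs3)c2)c1` differs from compound 1 by 3-chlorophenyl in place of 4-chlorophenyl on an aromatic carbon. Among the measured compounds shown here, no measured step touches the chlorophenyl group, and the measured steps at the other group were all within the scatter, so compound 4 is expected to show no change at the digits printed from compound 1 to compound 4 (within the scatter), nothing beyond the scatter. Compound 4 is estimated at 10500 nM in this assay, with a range from 4500 nM to 25000 nM.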

Compound 4, half-maximal inhibitory concentration: 3410 nM
Beside the measured number, compound 4's estimate is 3.1-fold (0.49 log units) above it, and the stated range ends above it.
By their numbers in this assay, from the lowest: compound 4; then compounds 1, 3 and 2 (each within the scatter of the next).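

In this assay, among the compounds shown here, 3-chlorophenyl in place of 4-chlorophenyl gives a 3.1-fold lower number from compound 1 to compound 4 (0.49 log units; beyond the scatter) and is the first step in this set to lie beyond the scatter. This position therefore responds to where the chlorine sits on the ring, although the swaps among thiophen-2-yl, thiophen-3-yl and furan-2-yl at the other position all stayed within the scatter. No evidence at hand bears on why the number falls. The compounds shown leave open whether the lower number carries over to the thiophen-3-yl and furan-2-yl compounds. They also leave open what an amine or a carboxylic acid in place of the chlorine would do.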